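Ketone aryl swap toward an aminomethylpyrimidine

The source may hold more compounds than are shown below. What is called first, only, known or untested is meant among the compounds shown, and "the series" means these compounds.

Compound 1 `COc1ccc(-c2cc3ccccc3nc2/C=C/C(=O)c2ccc(OC)cc2OC)cc1` carries a 2,4-dimethoxyphenyl on the carbonyl carbon of the enone. In a functional assay on H184B5F5/M10 cells (Homo sapiens) for antiproliferative activity, read by XTT assay, with a stated time of 72 h (a higher number here means a weaker inhibitor, a lower number a stronger inhibitor), compound 1 gives 6110 nM. Compound 2 `COc1ccc(-c2cc3ccccc3nc2/C=C/C(=O)c2cccs2)cc1` gives 7030 nM and compound 3 `COc1ccc(-c2cc3ccccc3nc2/C=C/C(=O)c2ccsc2)cc1` gives 6390 nM. Compound 1 has the lowest number of the three, but the steps of a 1.2-fold higher number from compound 1 to compound 2 (0.06 log units; within the scatter) and a 1.0-fold higher number from compound 1 to compound 3 (0.02 log units; within the scatter) are both within the scatter, as is a 1.1-fold lower number from compound 2 to compound 3 (0.04 log units; within the scatter), so across these three the group on the carbonyl carbon has not moved the read-out in any direction that can be trusted.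

Compound 4 `COc1ccc(-c2cc3ccccc3nc2/C=C/C(=O)c2cnc(N)nc2C)cc1` is the next change at the same place: 2-amino-4-methylpyrimidin-5-yl in place of 2,4-dimethoxyphenyl on a carbonyl carbon. The measured steps that bear on it are the two departures from the 2,4-dimethoxyphenyl, a 1.2-fold higher number from compound 1 to compound 2 (0.06 log units; within the scatter) and a 1.0-fold higher number from compound 1 to compound 3 (0.02 log units; within the scatter); each replaced that group with a different aromatic ring and neither moved the number beyond the scatter. The entering 2-amino-4-methylpyrimidin-5-yl lies outside what those two steps tested, so the coverage is partial and the range is kept wide. No step beyond the scatter is expected in this assay. Compound 4 is therefore estimated at 6000 nM, with a range of 2500 nM to 15000 nM, meaning an expected step of a 1.0-fold lower number from compound 1 to compound 4 (0.01 log units; within the scatter).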

Compound 4, half-maximal inhibitory concentration: > 10000 nM
Compound 4 gave a limit, no number; the forecaster's own chance of this, stated with the estimate: 5%; at least 1.6-fold (0.22 log units) between middle value and limit.
By their numbers in this assay, from the lowest: compounds 1, 3 and 2 (each within the scatter of the next). At a limit, above all of these: compound 4.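

In this assay compound 4 gives > 10000 nM, which is a limit and not a number, and it is the only compound shown whose reading ends this way: the limit of > 10000 nM in this assay, at which 1 of the 4 values shown sits. The steps to it are floors only: an at least 1.6-fold higher number from compound 1 to compound 4 (0.21 log units; that floor lies within the scatter), an at least 1.5-fold higher number from compound 3 to compound 4 (0.19 log units; that floor lies within the scatter) and an at least 1.4-fold higher number from compound 2 to compound 4 (0.15 log units; that floor lies within the scatter). Thiophen-2-yl and thiophen-3-yl gave measured numbers within the scatter of 2,4-dimethoxyphenyl, whereas 2-amino-4-methylpyrimidin-5-yl gives none, so the group on a carbonyl carbon can now take the read-out out of measurable range, though no loss beyond the scatter is established.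

The compounds shown leave open how far compound 4 really lies from the other three, and whether the limit goes with the amine, the methyl or the ring nitrogens of the entering group. A 4-methylpyrimidin-5-yl without the amine, or a pyridin-3-yl, on the same carbonyl carbon would bear on that question.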